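A larger ring on the sulfur of compound 2

The source may hold more compounds than are shown below. What is called first, only, known or untested is meant among the compounds shown, and "the series" means these compounds.

Going by the values given here, in a functional assay on HCT-116 cells (Homo sapiens) for cytotoxicity, read by MTT assay (on this read-out higher numbers stand for weaker inhibition and lower numbers for stronger inhibition), compound 2 (`Nc1ccccc1NC(=O)c1ccc(CSc2ncc[nH]2)cc1`) gives 5000 nM and holds the higher of the two numbers so far, making it the weaker inhibitor of the pair. Among the compounds with values here, the only other measured compound is compound 1 (`Nc1ccccc1NC(=O)c1ccc(CSc2nc3ccc(NCc4cccnc4)cc3s2)cc1`) at 1000 nM and the gap between the two lies beyond the usual scatter. Compound 3 (`Nc1ccccc1NC(=O)c1ccc(CSc2nc3ccccc3s2)cc1`) carries 1,3-benzothiazol-2-yl in place of 1H-imidazol-2-yl on a sulfur whose other neighbour is a saturated chain carbon (1,3-benzothiazol-2-yl in place of 1H-imidazol-2-yl on a sulfur). Within the data shown here, compound 1 also holds a 1,3-benzothiazol-2-yl group on that sulfur, though a substituted one, and this value of 1000 nM is the sole guide to the expectation. The estimated step is a 2.5-fold lower number from compound 2 to compound 3 (0.40 log units; beyond the scatter) and is expected to point toward stronger inhibition, modestly beyond the scatter. In this assay compound 3 is estimated at 2000 nM (expected range 700 nM to 5000 nM).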

Compound 3, half-maximal inhibitory concentration: 800 nM
Compound 3: the middle estimate sits 2.5-fold (0.40 log units) above what was measured; low and high end bracket the measured number.
By their numbers in this assay, from the lowest: compounds 3 and 1 (each within the scatter of the next); then compound 2.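

In this assay, the unsubstituted 1,3-benzothiazol-2-yl group in place of 1H-imidazol-2-yl on the sulfur gives a 6.3-fold lower number from compound 2 to compound 3 (0.80 log units; beyond the scatter) and so shows in a single-place comparison that this exchange alone moves the read-out toward stronger inhibition, which compound 1, differing from compound 2 in more than one place, could not show. The ((pyridin-3-yl)methyl)amino group on the aromatic carbon does not separate the other pair: hydrogen in its place gives a 1.3-fold lower number from compound 1 to compound 3 (0.10 log units; within the scatter) and stays within the scatter. No measurement at hand accounts for either step.

As far as these compounds go, whether the ring sulfur of 1,3-benzothiazol-2-yl matters remains open, and 1,3-benzoxazol-2-yl on the same sulfur would test that. Also open, from the compounds shown here alone, is whether a different group on that aromatic carbon, such as a carboxylic acid or a methoxy group, would stand apart from hydrogen.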